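Chloro for hydrogen on the outer phenyl ring

The source may report more compounds than this note shows. Statements on the series, on what has been measured and on what is new or still open speak of the compounds shown alone.

Measured so far:
compound 1, `CN1CCN(COc2ccc(-c3cc(-c4ccccc4)on3)cc2)CC1`: 6200 nM
compound 2, `CN1CCN(COc2ccc(-c3cc(-c4ccc(Cl)cc4)on3)cc2)CC1`: 1600 nM
compound 3, `CN(C)CCCOc1ccc(-c2cc(-c3ccccc3)no2)cc1`: 6700 nM

All three were tested in an assay on isolated protein for inhibition of C-X-C chemokine receptor type 1 (Homo sapiens), read by radioligand binding; a lower number here means a stronger inhibitor, a higher number a weaker inhibitor. Compound 1 and compound 2 share a core; their difference is chloro in place of hydrogen on an aromatic carbon, and the step of a 3.9-fold lower number from compound 1 to compound 2 (0.59 log units; beyond the scatter). Compound 3 carries a different core; the difference between the two cores is not broken down here. In this assay compound 3 gives 6700 nM, close to compound 1.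

Compound 4, `CN(C)CCCOc1ccc(-c2cc(-c3ccc(Cl)cc3)no2)cc1`, is not yet measured. It differs from compound 3 by chloro in place of hydrogen on an aromatic carbon, the same change as that from compound 1 to compound 2. Resting on that single earlier step, the expected step is a 3.5-fold lower number from compound 3 to compound 4 (0.55 log units; beyond the scatter), giving an estimated value for compound 4 of 1900 nM, with a likely range from 800 nM to 4500 nM.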

Compound 4, half-maximal inhibitory concentration: 3900 nM
Compound 4: middle estimate off by 2.1-fold (0.31 log units), on the low side; low and high end bracket the measured number.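

In this assay, phenyl to 4-chlorophenyl on the core of compound 3 gives a 1.7-fold lower number from compound 3 to compound 4 (0.24 log units; within the scatter). This step and the earlier one on the core of compound 1 do not differ beyond what two such steps can scatter: the same change on two cores in this assay, a 3.9-fold lower number (0.59 log units; beyond the scatter) from compound 1 to compound 2 and a 1.7-fold lower number (0.24 log units; within the scatter) from compound 3 to compound 4, 2.3-fold (0.35 log units) apart, within the scatter of two such steps. Among the compounds shown here, the pairs are compatible with the change carrying across the two cores, but two pairs do not establish that, and they do not fix its size on either core, as only the step on the core of compound 1 lies beyond the scatter.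

On these data alone, whether fluoro, methyl or methoxy in place of chloro would behave in the same way remains open. Also open, as far as these compounds go, is how the change would fare with a longer chain or a morpholine in place of the dimethylamino end of compound 4.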